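This account rests on a few compounds, and the source may have more. Where it says the series, first, only, none or still open, it means among the compounds named here.

In an assay on HEK293 cells for inhibition of solute carrier family 22 member 12 (Homo sapiens) (on this read-out lower numbers stand for stronger inhibition and higher numbers for weaker inhibition), three compounds built on a shared core have been measured. Compound 1 `NS(=O)(=O)CSc1nnc(Br)n1Cc1ccc(Br)c2ccccc12` carries a bare sulfonamide and gives 365000 nM. Compound 2 `O=S(=O)(CSc1nnc(Br)n1Cc1ccc(Br)c2ccccc12)Nc1cncc(C(F)(F)F)c1` gives 6380 nM, and compound 3 `O=S(=O)(CSc1nnc(Br)n1Cc1ccc(Br)c2ccccc12)Nc1ccc(Cl)nc1Cl` gives 1660 nM, the lowest number of the three and the strongest inhibition. The step of a 220-fold lower number from compound 1 to compound 3 (2.34 log units; beyond the scatter) and the step of a 57-fold lower number from compound 1 to compound 2 (1.76 log units; beyond the scatter) both show that a substituted pyridinyl ring on the sulfonamide nitrogen matters a great deal, while the step of a 3.8-fold lower number from compound 2 to compound 3 (0.58 log units; beyond the scatter) shows that the choice between two such rings matters less.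

Compound 4 `COc1ncccc1NS(=O)(=O)CSc1nnc(Br)n1Cc1ccc(Br)c2ccccc12` has not yet been measured. It differs from compound 3 by 2-methoxypyridin-3-yl in place of 2,6-dichloropyridin-3-yl on a sulfonamide nitrogen. Among the compounds with values here, the measured step that bears most directly on this is the step of a 3.8-fold lower number from compound 2 to compound 3 (0.58 log units; beyond the scatter), a modest change when one substituted pyridinyl ring replaced another; the two large steps show only that removing the ring altogether is far more costly. Since compound 4 keeps a pyridinyl ring on the nitrogen, a step of modest size is expected, most likely towards a higher number, because compound 3 gives 1660 nM and this is the lowest number seen so far. The expected step is a 3.0-fold higher number from compound 3 to compound 4 (0.48 log units; beyond the scatter). Compound 4 is therefore estimated at 5000 nM, with a range from 1500 nM to 20000 nM.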

Compound 4, half-maximal inhibitory concentration: 4050 nM
The estimate for compound 4 lay 1.2-fold (0.09 log units) above the measured number; the measured number falls inside the stated range.
By their numbers in this assay, from the lowest: compound 3; then compounds 4 and 2 (each within the scatter of the next); then compound 1.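

In this assay, 2-methoxypyridin-3-yl on the sulfonamide nitrogen also brings a large gain over the bare sulfonamide, with a 90-fold lower number from compound 1 to compound 4 (1.95 log units; beyond the scatter), which shows that this gain does not depend on a halogen atom on the ring. Replacing 2,6-dichloropyridin-3-yl with 2-methoxypyridin-3-yl gives only a 2.4-fold higher number from compound 3 to compound 4 (0.39 log units; beyond the scatter), while a 1.6-fold lower number from compound 2 to compound 4 (0.20 log units; within the scatter) lies within the scatter, so these two compounds cannot be told apart although their rings carry different groups. Nothing measured here accounts for these differences.

The compounds shown leave open which part of each ring matters, as the three rings differ in both the groups they carry and where those groups sit. From the compounds shown here alone, it also remains open whether an unsubstituted pyridin-3-yl ring, a plain phenyl ring, or a ring bearing a single chlorine would give a number close to those of the three substituted pyridinyl rings, or whether a simple methyl group on the same nitrogen would give a number closer to that of the bare sulfonamide.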